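Benzoylmethyl for Phenylcarbamoyl: an Expected Step

The compounds below may be only part of what the source reports. "The series", "measured", "known", "first", "only" and "open" are said of these compounds alone.

Among the measured compounds shown here, compound 2 `O=C(C[C@@H]1CCCCN1C(=O)c1ccccc1-c1ccccc1)Nc1ccccc1` gives 31.6 nM in a functional assay on CHO cells for antagonist activity at Orexin receptor type 2 (Homo sapiens), read by FLIPR (a higher number here means a weaker inhibitor, a lower number a stronger inhibitor), the higher of the two numbers recorded, while compound 1 `O=C(c1ccccc1-c1ccccc1)N1CCCC[C@H]1CCOc1ccc(F)cc1F` gives 0.794 nM in this assay; the step of a 40-fold higher number from compound 1 to compound 2 (1.60 log units; beyond the scatter) is the only measured change at this place. Compound 3 `O=C(CC[C@@H]1CCCCN1C(=O)c1ccccc1-c1ccccc1)c1ccccc1` carries benzoylmethyl in place of phenylcarbamoyl on a saturated chain carbon bound to a saturated ring carbon. For the measured compounds named here, no measured step makes this exchange, and the one step at the same position concerned a different group, so only a loose expectation is possible. The step of a 2.6-fold lower number from compound 2 to compound 3 (0.42 log units; beyond the scatter) is expected to be modest, toward a lower number. Compound 3 is therefore estimated at 12 nM in this assay, between 2.5 nM and 60 nM.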

Compound 3, inhibition constant: 20 nM
For compound 3 the middle estimate is 1.7-fold (0.22 log units) below the measured one; low and high end bracket the measured number.
By their numbers in this assay, from the lowest: compound 1; then compounds 3 and 2 (each within the scatter of the next).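

In this assay the exchange of phenylcarbamoyl for benzoylmethyl, with 0 hydrogen-bond donors in place of 1, gives a 1.6-fold lower number from compound 2 to compound 3 (0.20 log units; within the scatter) and the two groups cannot be told apart at this place. Benzoyl in place of 2,4-difluorophenoxy gives a 25-fold higher number from compound 1 to compound 3 (1.40 log units; beyond the scatter) and so the large gap to compound 1 persists without the amide hydrogen. Nothing given here accounts for these numbers.

Going by these compounds, it remains open whether an amine in place of the carbonyl, or a plain phenyl on a longer chain, would come back toward compound 1. On these data alone, it is also open whether the fluorines of 2,4-difluorophenoxy or its ether oxygen carry the difference.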